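The source may hold more compounds than are shown below. What is called first, only, known or untested is meant among the compounds shown, and "the series" means these compounds.

Measured so far in a functional assay on CHO cells for positive allosteric modulation of metabotropic glutamate receptor 2 (Homo sapiens), read by scintillation counting and GTPgammaS binding, with a stated time of 30 min; a lower number here means that less compound is needed, a higher number that more compound is needed for the effect:
- compound 1 `CCCCn1ccc(-c2ccc(Oc3ccnc(C)c3)cc2)c(C#N)c1=O` gives 398 nM
- compound 2 `CCCCn1ccc(-c2ccc(Oc3ccnc(C)c3)c(Cl)c2)c(C#N)c1=O` gives 166 nM
- compound 3 `CCCCn1ccc(-c2ccc(Oc3ccc(C)nc3C)c(Cl)c2)c(C#N)c1=O` gives 30 nM

Compound 2 holds the second highest of the three numbers. Its nearest neighbour is compound 1, from which it differs by the chloro on the aromatic carbon, the step being a 2.4-fold lower number from compound 1 to compound 2 (0.38 log units; beyond the scatter). Its furthest neighbour is compound 3, reached by a 5.5-fold lower number from compound 2 to compound 3 (0.74 log units; beyond the scatter).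

Compound 4 `CCCCn1ccc(-c2ccc(Oc3ccnc(C)c3)c(F)c2)c(C#N)c1=O` is the next member. Against compound 2 the change is fluoro in place of chloro on an aromatic carbon. Within the data shown here, the only measured step that bears on this position is the one from compound 1 to compound 2, which put the chloro in and gave a modest drop in the number. Among the measured compounds shown here, compound 4 keeps a substituent there but not the same one, and no measured pair shows a fluoro at this place. The expectation is therefore a number somewhere between those of compound 1 and compound 2, with the step of a 1.5-fold higher number from compound 2 to compound 4 (0.18 log units; within the scatter) expected to be small and possibly within the scatter. Compound 4 is estimated at 250 nM, in a range from 120 nM to 520 nM.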

Compound 4, half-maximal effective concentration: 316 nM
Estimate against measurement, compound 4: 1.3-fold (0.10 log units) below; measured number inside the range.
By their numbers in this assay, from the lowest: compound 3; then compounds 2, 4 and 1 (each within the scatter of the next, the first and the last beyond it).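

In this assay, fluoro and chloro cannot be told apart at this place, ortho to the (2-methylpyridin-4-yl)oxy group, with a 1.9-fold higher number from compound 2 to compound 4 (0.28 log units; within the scatter) for the exchange. Fluoro cannot be told apart from hydrogen there either, with a 1.3-fold lower number from compound 1 to compound 4 (0.10 log units; within the scatter), so compound 4 lies within the scatter of both neighbours. Among these compounds, of the three steps at this place, only the one that brings in chloro, a 2.4-fold lower number from compound 1 to compound 2 (0.38 log units; beyond the scatter), lies beyond the scatter, and fluoro neither confirms nor refutes a shared gain from a substituent here; no measurement at hand explains any of these steps.

Still open, going by these compounds, is how a bromo, a methoxy or a trifluoromethyl group would read at this place. Also open, on these data alone, is whether fluoro in place of chloro reads the same with the 2,6-dimethylpyridin-3-yl group of compound 3 on the oxygen.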